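The source may hold more compounds than are shown below. What is called first, only, known or untested is meant among the compounds shown, and "the series" means these compounds.

The measured compounds:
Compound 1 `COc1cc(CN(C(=O)Nc2ccc(C)cc2)n2cnnc2)cc(OC)c1OC` gives in a functional assay on MDA-MB-231 cells (Homo sapiens) for cytotoxicity, read by MTT assay, with a stated time of 48 h (a higher number here means a weaker inhibitor, a lower number a stronger inhibitor), a value of > 50000 nM, which is a limit of the assay and not a number.
Compound 2 `O=C(NCc1ccccc1)N(Cc1ccccn1)n1cnnc1` gives in this assay a value of > 50000 nM, likewise a limit of the assay rather than a number.

Compound 2 therefore stands at the limit itself, and it is not alone there: the limit of > 50000 nM in this assay, at which 2 of the 2 values shown sit. For the measured compounds named here, no step between measured compounds can be read, since both values are limits. Compound 3 `O=C(Nc1ccccc1)N(Cc1ccccn1)n1cnnc1` has not yet been measured in this assay; it differs from compound 2 by phenyl in place of benzyl on an amide-type nitrogen. With compound 2 sitting at the limit in this assay (> 50000 nM), no direction can be taken from the numbers. Compound 3 is therefore expected to stay near the limit, with a step of a number no higher from compound 2 to compound 3 (the limit leaves the size open) that amounts to none beyond the scatter. The estimate for compound 3 in this assay is 50000 nM, ranging from 20000 nM to 120000 nM.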

Compound 3, half-maximal inhibitory concentration: > 50000 nM
Compound 3: only a limit was reported; the forecaster's own chance of this, stated with the estimate: 80%; the middle value lies on the limit itself.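

No new step can be read between compound 2 and compound 3, since both values are limits of the assay and not numbers: the limit of > 50000 nM in this assay, at which 3 of the 3 values shown sit.
In this assay the compounds shown leave open how far each lies beyond that limit, and whether phenyl and benzyl differ at all.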